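The source may hold more compounds than are shown below. What is called first, only, known or untested is meant among the compounds shown, and "the series" means these compounds.

Measured compounds in a functional assay on A9L-m1 cells with A9 (Mus musculus) as the target; a higher number here means a larger maximal response, a lower number a smaller maximal response:
compound 1 `Cc1nccnc1C1CN2CCC1CC2`, 4%
compound 2 `Clc1nccnc1C1CN2CCC1CC2`, 13%
compound 3 `COc1nccnc1C1CN2CCC1CC2`, 1%

All three maximal responses are small, and compound 1 sits amid them: the step of a number 9 percentage points higher from compound 1 to compound 2 (within the scatter) and the step of a number 3 percentage points lower from compound 1 to compound 3 (within the scatter) are both within the scatter, so no order among compounds 1, 2 and 3 can be read from these numbers. Among the compounds with values here, only the step of a number 12 percentage points lower from compound 2 to compound 3 (beyond the scatter) reaches beyond the scatter.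

Compound 4 `CCCCOc1nccnc1C1CN2CCC1CC2` differs from compound 1 in one place: butoxy in place of methyl on an aromatic carbon. The step that bears most directly on this change is the one in which an alkoxy group also replaces the methyl, a number 3 percentage points lower from compound 1 to compound 3 (within the scatter), which stayed within the scatter. The step of a number 12 percentage points lower from compound 2 to compound 3 (beyond the scatter) points the same way, downward, but starts from a different group. Expected for compound 4 is therefore a small change at most, likely downward, a number 1 percentage points lower from compound 1 to compound 4 (within the scatter), with the maximal response estimated at 3% within a range of 0% to 12%.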

Compound 4, largest response reached (reported as maximum), in percent of the reference or control that the assay uses: 15%
Beside the measured number, compound 4's estimate is 12 percentage points below it, outside the stated range (above it).
By their numbers in this assay, from the lowest: compounds 3, 1, 2 and 4 (each within the scatter of the next, the first and the last beyond it).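

In this assay, the size of the alkoxy group at this aromatic carbon matters: butoxy gives a number 14 percentage points higher from compound 3 to compound 4 (beyond the scatter) and a number 11 percentage points higher from compound 1 to compound 4 (beyond the scatter), so an alkoxy group here does not by itself hold the response low. Butoxy and chloro cannot be told apart, with a number 2 percentage points higher from compound 2 to compound 4 (within the scatter). No measurement at hand explains the higher response of compound 4. Open, going by these compounds, is whether the response climbs gradually or abruptly between methoxy and butoxy. Also open, on these data alone, is whether a longer chain or an amine at this carbon would take the maximal response beyond that of compound 4.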